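The source may hold more compounds than are shown below. What is called first, only, known or untested is meant among the compounds shown, and "the series" means these compounds.

Measured compounds in the series:
compound 1 `CCOc1cccc(/C=N/c2c(C)n(C)n(-c3ccccc3)c2=O)c1`, in a functional assay on HT-29 cells (Homo sapiens) for cytotoxicity, read by MTT assay, with a stated time of 72 h (on this read-out higher numbers stand for weaker inhibition and lower numbers for stronger inhibition), compound 1 gives 295000000 nM;
compound 2 `COc1ccc(/C=N/c2c(C)n(C)n(-c3ccccc3)c2=O)cc1`, in this assay compound 2 gives 589000000 nM;
compound 3 `Cc1c(/N=C/c2cccc(O)c2)c(=O)n(-c2ccccc2)n1C`, in this assay compound 3 gives 166000000 nM.

Compound 3 has the lowest number of the three in this assay, but only the gap to compound 2 lies beyond the scatter; against compound 1 it is within scatter, so no order between compound 1 and compound 3 is claimed.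

Compound 4 `Cc1c(/N=C/c2ccccc2Cl)c(=O)n(-c2ccccc2)n1C` is not yet measured. It differs from compound 3 by 2-chlorophenyl in place of 3-hydroxyphenyl on a carbon with a double bond to nitrogen. For the measured compounds named here, the steps that bear on this are the ones that changed the aryl on the same carbon: a 1.8-fold lower number from compound 1 to compound 3 (0.25 log units; within the scatter) and a 3.5-fold lower number from compound 2 to compound 3 (0.55 log units; beyond the scatter). Both are small, and the one beyond scatter moved the number down on gaining the hydroxyl. Compound 4 gives up that hydroxyl and gains chlorine, a change not yet sampled, so at most a modest upward step in this assay is expected, possibly none beyond the scatter, as a 1.6-fold higher number from compound 3 to compound 4 (0.19 log units; within the scatter). Compound 4 is therefore estimated at 260000000 nM, with a range from 100000000 nM to 700000000 nM.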

Compound 4, half-maximal inhibitory concentration: 309000000 nM
Compound 4: the middle estimate sits 1.2-fold (0.07 log units) below what was measured; the range from low to high includes it.
By their numbers in this assay, from the lowest: compounds 3, 1, 4 and 2 (each within the scatter of the next, the first and the last beyond it).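

In this assay, 2-chlorophenyl on the carbon with a double bond to nitrogen gives a number within the scatter of both neighbouring aryl variants (a 1.9-fold higher number from compound 3 to compound 4 (0.27 log units; within the scatter); a 1.9-fold lower number from compound 2 to compound 4 (0.28 log units; within the scatter)). The earlier gap between compound 2 and compound 3 left the hydroxyl as the one change beyond the scatter, but compound 4 carries no hydrogen-bond donor or acceptor on this aryl and is not separated from compound 3, so the hydroxyl is not shown to be needed at this position. Nothing at hand explains these small steps.

As far as these compounds go, whether an amine or a carboxylic acid on this aryl, or a longer alkyl chain in place of the aryl, would move the number beyond the scatter remains open. Also open, from the compounds shown here alone, is whether any change at this position would bring the number far below that of compound 3, 166000000 nM.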